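Chloro to Fluoro on Two Different Rings

The source may report more compounds than this note shows. Statements on the series, on what has been measured and on what is new or still open speak of the compounds shown alone.

Measured so far in a functional assay on Raji cells (Homo sapiens) for cytotoxicity, read by MTT assay, with a stated time of 48 h; on this read-out lower numbers stand for stronger inhibition and higher numbers for weaker inhibition:
compound 1, `O=C(O)CN1C(=O)/C(=C/c2nc3ccccc3n2Cc2ccc(F)cc2)SC1=S`: 1770 nM
compound 2, `O=C(O)CN1C(=O)/C(=C/c2nc3ccccc3n2Cc2ccc(Cl)cc2)SC1=S`: 11400 nM
compound 3, `Cc1ccc(Cn2c(/C=C3\SC(=S)N(CC(=O)O)C3=O)nc3ccc(Cl)cc32)cc1`: 2790 nM

Among the measured compounds shown here, the only single-point step in this assay is a 6.4-fold lower number from compound 2 to compound 1 (0.81 log units; beyond the scatter), the change being (fluoro in place of chloro on an aromatic carbon). Compound 3 differs from compound 2 in more than one place; the difference between the two cores is not broken down here. Compound 3 stands within the scatter of compound 1 and beyond it relative to compound 2.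

Compound 4 `Cc1ccc(Cn2c(/C=C3\SC(=S)N(CC(=O)O)C3=O)nc3ccc(F)cc32)cc1` is not yet measured and differs from compound 3 by fluoro in place of chloro on an aromatic carbon. This is the same kind of change as from compound 2 to compound 1, not the same: there the place was para to a large group on a ring of carbon only, here it is part of a fused or bridged system of two rings, meta to a fused ring and para to a fused ring. For the measured compounds named here, for compound 4 the expected step is a 2.0-fold lower number from compound 3 to compound 4 (0.30 log units; within the scatter), smaller than the earlier one, because the only precedent a 6.4-fold lower number from compound 2 to compound 1 (0.81 log units; beyond the scatter) lies on another ring. Compound 4 is estimated at 1400 nM, between 500 nM and 4000 nM.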

Compound 4, half-maximal inhibitory concentration: 2440 nM
Compound 4: the middle estimate sits 1.7-fold (0.24 log units) below what was measured, and the stated range covers the measured number.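

In this assay, fluoro in place of chloro on the fused system of two rings gives a 1.1-fold lower number from compound 3 to compound 4 (0.06 log units; within the scatter), a step that stays within the scatter. The same kind of change therefore did not carry its size over from one core to the other: the same change on two cores in this assay, a 6.4-fold lower number (0.81 log units; beyond the scatter) from compound 2 to compound 1 and a 1.1-fold lower number (0.06 log units; within the scatter) from compound 3 to compound 4, 5.6-fold (0.75 log units) apart, beyond the scatter of two such steps. With one pair on each core, and with the change sitting on a different ring in each pair, these compounds cannot show whether the ring bearing the halogen or the rest of the core sets the size of the step.

As far as these compounds go, it remains open how an amine or a methoxy group would read on that same aromatic carbon. From the compounds shown here alone, it is also open whether a longer chain carrying the carboxylic acid would alter the picture.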